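Cyano for Trifluoromethyl at the Benzyl End

The compounds below may be only part of what the source reports. "The series", "measured", "known", "first", "only" and "open" are said of these compounds alone.

compound 1 `O[C@H](COCCOC[C@@H](O)Cc1cn(Cc2ccc3ccccc3c2)nn1)Cc1ccc(-c2ccccc2)cc1`: 12100 nM
compound 2 `O[C@H](COCCOC[C@@H](O)Cc1cn(-c2cncnc2)nn1)Cc1ccc(-c2ccccc2)cc1`: > 100000 nM, a limit of the assay and not a number
compound 3 `O[C@H](COCCOC[C@@H](O)Cc1cn(Cc2ccc(C(F)(F)F)cc2)nn1)Cc1ccc(-c2ccccc2)cc1`: 8700 nM

All three share one core and differ only in the group carried on the aromatic nitrogen. In a functional assay on SGC-7901 cells (Homo sapiens) for inhibition, read by MTT assay, with a stated time of 72 h (on this read-out higher numbers stand for weaker inhibition of growth and lower numbers for stronger inhibition of growth), compound 3 gives the lower of the two numbers, but compound 1 sits close to it: a 1.4-fold lower number from compound 1 to compound 3 (0.14 log units; within the scatter). Compound 2 stands apart, having reached only the limit (the limit of > 100000 nM in this assay, at which 1 of the 3 values shown sits), so the step of an at least 8.2-fold higher number from compound 1 to compound 2 (0.91 log units; beyond the scatter) and the step of an at least 11-fold lower number from compound 2 to compound 3 (1.06 log units; beyond the scatter) are both clear losses when a benzyl-type group is replaced by pyrimidin-5-yl directly on the nitrogen.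

Compound 4 `N#Cc1ccc(Cn2cc(C[C@H](O)COCCOC[C@@H](O)Cc3ccc(-c4ccccc4)cc3)nn2)cc1` keeps the benzyl group and changes only the substituent on it: cyano in place of trifluoromethyl on an aromatic carbon. For the measured compounds named here, no measured step swaps one such substituent for another, so the nearest guide is a 1.4-fold lower number from compound 1 to compound 3 (0.14 log units; within the scatter), where a different aromatic group on the same chain carbon moved the number only within the scatter. The expected step is therefore small, with no clear direction: a 1.0-fold higher number from compound 3 to compound 4 (0.01 log units; within the scatter). Compound 4 is estimated in this assay at 9000 nM, within a range from 3500 nM to 25000 nM.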

Compound 4, concentration for 50% growth inhibition: 7700 nM
Beside the measured number, compound 4's estimate is 1.2-fold (0.07 log units) above it; measured number inside the range.
By their numbers in this assay, from the lowest: compounds 4, 3 and 1 (each within the scatter of the next). At a limit, above all of these: compound 2.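

In this assay, for the compounds shown here, this is the first direct swap of one substituent for another on the six-membered aromatic ring of carbon only, and it leaves the read-out unmoved: a 1.1-fold lower number from compound 3 to compound 4 (0.05 log units; within the scatter), and the comparison with the naphthalen-2-yl group gives a 1.6-fold lower number from compound 1 to compound 4 (0.20 log units; within the scatter), so neither step lies beyond the scatter. At this place, then, cyano with its 2 heavy atoms and 1 hydrogen-bond acceptor reads the same as trifluoromethyl with its 4 heavy atoms and no acceptor, although two groups are too few to make a rule for the position. The gap to the directly attached pyrimidin-5-yl group holds for the 4-cyanobenzyl group too, with an at least 12-fold lower number from compound 2 to compound 4 (1.11 log units; beyond the scatter), but compound 2 gives only a limit of the assay and not a number, so the true size of that step stays unknown: the limit of > 100000 nM in this assay, at which 1 of the 4 values shown sits.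

The compounds shown leave open whether the number would stay flat with an amine or a carboxylic acid on this ring carbon, or with a plain hydrogen there. They also leave open what a longer chain between the aromatic nitrogen and the ring would do, and why the two substituents read alike.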